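The source may hold more compounds than are shown below. What is called first, only, known or untested is meant among the compounds shown, and "the series" means these compounds.

Compound 1 `O=[N+]([O-])c1cn2c(n1)OC[C@@H](OCc1ccc(-c3ccc(OC(F)(F)F)cc3)cc1)C2`: in an ADME assay on Vero cells (Chlorocebus sabaeus) for cytotoxicity, with a stated time of 72 h (on this read-out lower numbers stand for stronger inhibition and higher numbers for weaker inhibition), compound 1 gives > 128000 nM, which is a limit of the assay.
Compound 2 `COc1ccc(-c2cccc(CO[C@@H]3COc4nc([N+](=O)[O-])cn4C3)c2)cc1F`: in this assay compound 2 gives > 128000 nM, likewise a limit.
Compound 3 `O=[N+]([O-])c1cn2c(n1)OC[C@@H](OCc1ccc(-c3ccc(C(F)(F)F)cc3)s1)C2`: in this assay compound 3 gives > 128000 nM, again a limit.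

Compound 3 therefore stands at the assay limit, as do the two other measured compounds; no numerical value separates any of the three (the limit of > 128000 nM in this assay, at which 3 of the 3 values shown sit). Compound 4 `N#Cc1ccc(-c2ccc(CO[C@@H]3COc4nc([N+](=O)[O-])cn4C3)s2)cc1` differs from compound 3 by cyano in place of trifluoromethyl on an aromatic carbon. Among the measured compounds shown here, no step between measured compounds is available, so the size of the change expected in this assay cannot be read from a measured pair; the three limits give no sign of a direction, and no step beyond the scatter is assumed. Compound 4 is expected at 150000 nM, between 60000 nM and 400000 nM, which means an expected step that the limit leaves unreadable from compound 3 to compound 4.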

Compound 4, half-maximal inhibitory concentration: > 128000 nM
Compound 4: a limit, no number (the forecaster's own chance of this, stated with the estimate: 85%); the middle value does not contradict the limit.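

No step can be read from compound 3 to compound 4 in this assay, since both values are limits and not numbers: the limit of > 128000 nM in this assay, at which 4 of the 4 values shown sit.

Left open is whether cyano in place of trifluoromethyl on an aromatic carbon changes the read-out at all in this assay.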